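The source may hold more compounds than are shown below. What is called first, only, known or untested is meant among the compounds shown, and "the series" means these compounds.

Measured compounds in a functional assay on SMMC-7721 cells (Homo sapiens) for cytotoxicity, read by MTT assay, with a stated time of 4 days; on this read-out lower numbers stand for stronger inhibition and higher numbers for weaker inhibition:
- compound 1, `C=C1C[C@]23C[C@@]1(O)CC[C@H]2c1ccc(OS(=O)(=O)c2ccc(C)cc2)c(C)c1[C@@H]3Cn1cc(-c2ccc(Br)cc2)nn1`, gives > 20000 nM, which is a limit of the assay and not a number
- compound 2, `C=C1C(=O)[C@]23C[C@@]1(O)CC[C@H]2c1ccc(OS(=O)(=O)c2ccc(C)cc2)c(C)c1[C@@H]3Cn1cc(-c2ccc(Cl)cc2)nn1`, gives 6180 nM
- compound 3, `C=C1C(=O)[C@]23C[C@@]1(O)CC[C@H]2c1ccc(O)c(C)c1[C@@H]3Cn1cc(-c2ccccc2)nn1`, gives 1320 nM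

Compound 3 gives the lowest of the two numbers shown in this assay; its nearest neighbour is compound 2, whose number is higher by a gap beyond the usual scatter. Compound 1 sits at the limit described in the limit of > 20000 nM in this assay, at which 1 of the 3 values shown sits, so its value cannot be ranked against the others. Among the compounds with values here, compounds 2 and 3 differ from each other in more than one place, so their two values show only that compound 3 is the more potent of the pair.

Compound 4, `C=C1C(=O)[C@]23C[C@@]1(O)CC[C@H]2c1ccc(O)c(C)c1[C@@H]3Cn1cc(-c2ccc(F)cc2)nn1`, is the next compound to be measured. It differs from compound 3 by fluoro in place of hydrogen on an aromatic carbon. Within the data shown here, no measured pair in this set shows that change alone, so the step is expected to be small, with no direction set by the data, and the estimated step is a 1.0-fold lower number from compound 3 to compound 4 (0.01 log units; within the scatter). On that basis compound 4 is expected to give about 1300 nM, within a range of 500 nM to 3500 nM.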

Compound 4, half-maximal inhibitory concentration: 850 nM
Estimate against measurement, compound 4: 1.5-fold (0.18 log units) above; measured number inside the range.
By their numbers in this assay, from the lowest: compounds 4 and 3 (each within the scatter of the next); then compound 2. At a limit, above all of these: compound 1.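

In this assay, the step from phenyl to 4-fluorophenyl is the only one shown that changes a single place, with fluoro in place of hydrogen on an aromatic carbon para to a large group, and it reads a 1.6-fold lower number from compound 3 to compound 4 (0.19 log units; within the scatter). At this position of the six-membered aromatic ring, then, hydrogen and fluoro cannot be told apart in this assay, so the position accepts this single atom with the value staying within the usual scatter. Nothing in the data shown bears on the reason for this result.

Going by these compounds, how an amine, a carboxylic acid or a methoxy group at this position would read remains open. Chloro and bromo at this position also remain open, since compound 1 and compound 2, which carry them, differ from compound 3 in more than one place.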